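From carboxy to (1H-tetrazol-5-yl)methyl on one core

The compounds below may be only part of what the source reports. "The series", "measured", "known", "first", "only" and "open" are said of these compounds alone.

compound 1 `O=C(O)c1ccc(COc2cccc(OCc3ccc4ccccc4n3)c2)cc1` gives 75 nM
compound 2 `COc1cc(COc2cccc(OCc3ccc4ccccc4n3)c2)cc(-c2nn[nH]n2)c1` gives 6.3 nM
compound 3 `COc1cc(-c2nn[nH]n2)ccc1COc1cccc(OCc2ccc3ccccc3n2)c1` gives 9 nM

All three values come from a functional assay (lung) for inhibition, with Cavia porcellus as the target (on this read-out higher numbers stand for weaker inhibition and lower numbers for stronger inhibition), and are the only data at hand. Compound 1 stands highest of the three at 75 nM and its gaps to compound 2 and to compound 3 both lie beyond the scatter, while those two lie within the scatter of each other.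

Compound 4 (`c1cc(OCc2ccc(Cc3nnn[nH]3)cc2)cc(OCc2ccc3ccccc3n2)c1`) has not yet been measured. It keeps the core of compound 1 and carries (1H-tetrazol-5-yl)methyl in place of carboxy on an aromatic carbon, para to a large group ((1H-tetrazol-5-yl)methyl in place of carboxy on an aromatic carbon).

For the measured compounds named here, no pair of measured compounds differs in one place only, so the comparison is loose. Compound 2 at 6.3 nM and compound 3 at 9 nM carry a 1H-tetrazol-5-yl group and no carboxy, but they differ from compound 1 in more than one place and lack the methyl link of compound 4. A lower number than that of compound 1 is therefore expected in this assay for this change. The estimated change is a 3.8-fold lower number from compound 1 to compound 4 (0.57 log units; beyond the scatter) and would probably lie beyond the scatter. Compound 4 is expected at 20 nM in a range from 5 nM to 75 nM on this estimate.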

Compound 4, half-maximal inhibitory concentration: 20 nM
Compound 4: middle estimate and measured number agree at the digits printed, and the stated range covers the measured number.
By their numbers in this assay, from the lowest: compounds 2 and 3 (each within the scatter of the next); then compound 4; then compound 1.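

In this assay the core of compound 1 now has a reading for this change alone: (1H-tetrazol-5-yl)methyl in place of carboxy on an aromatic carbon, para to a large group, gives a 3.8-fold lower number from compound 1 to compound 4 (0.57 log units; beyond the scatter) with the rest of the structure unchanged. Compounds 2 and 3 could not show this, as each differs from compound 1 in more than one place and neither carries the methyl link. The step shows that at this position carboxy can give way to a larger group with one five-membered aromatic ring and still yield stronger inhibition, though nothing at hand gives a reason for the step.

As far as these compounds go, the step joins two changes, the ring and the methyl link, so what each contributes stays open: 1H-tetrazol-5-yl set directly on the same aromatic carbon of this core, or a carboxymethyl group there, would separate them. Also open, from the compounds shown here alone, is how a longer chain, such as 2-(1H-tetrazol-5-yl)ethyl, would read at this position.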